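Compound 1 to compound 4: dropping the fluoro

The source may hold more compounds than are shown below. What is called first, only, known or untested is meant among the compounds shown, and "the series" means these compounds.

Compound 1 `COC(=O)c1scc(-c2ccc(NC(=O)c3cc(I)ccc3F)cc2)c1OC` stands highest of the two numbers in a functional assay on K562 cells (Homo sapiens) for antiproliferative activity, read by MTT assay, with a stated time of 24 h (a lower number here means a stronger inhibitor, a higher number a weaker inhibitor), giving 35600 nM; compound 3 `COC(=O)c1scc(-c2ccc(NC(=O)c3ccc(F)c(Cl)n3)cc2)c1OC` gives 8250 nM, and for compound 2 `COC(=O)c1scc(-c2ccc(NC(=O)c3ccc(C#N)nc3)cc2)c1OC` the entry reads "not determined" (no result reported). Among the measured compounds shown here, the only measured step, a 4.3-fold lower number from compound 1 to compound 3 (0.63 log units; beyond the scatter), exchanges one whole ring for another on the carbonyl carbon. Compound 4 `COC(=O)c1scc(-c2ccc(NC(=O)c3cccc(I)c3)cc2)c1OC` differs from compound 1 by hydrogen in place of fluoro on an aromatic carbon. For the measured compounds named here, a ring exchange says nothing about removing a single fluoro, so no measured step bears on this change, and the expectation rests on compound 1 alone. Compound 4 is therefore expected to stay within the scatter, with a 1.0-fold lower number from compound 1 to compound 4 (0.01 log units; within the scatter). The estimate for compound 4 in this assay is 35000 nM, in a range from 12000 nM to 100000 nM.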

Compound 4, half-maximal inhibitory concentration: 14700 nM
The estimate for compound 4 lay 2.4-fold (0.38 log units) above the measured number, within the range that was stated.
By their numbers in this assay, from the lowest: compounds 3 and 4 (each within the scatter of the next); then compound 1.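

In this assay the fluoro, ortho to a large group and para to an iodo group, proves to matter on its own: hydrogen in its place gives a 2.4-fold lower number from compound 1 to compound 4 (0.38 log units; beyond the scatter) as a modest change. The 3-iodophenyl group in place of the 6-chloro-5-fluoropyridin-2-yl group gives a 1.8-fold higher number from compound 3 to compound 4 (0.25 log units; within the scatter) and so does not separate these two rings. Nothing available explains either step.

Open, going by these compounds, is how an amine or a methoxy group would compare with hydrogen at this place. Also open, on these data alone, is what the iodo group contributes, which a chloro group or a nitrile in its place would address.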